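The compounds below may be only part of what the source reports. "The series", "measured", "known", "first", "only" and "open" are said of these compounds alone.

Measured compounds:
compound 1, `CCOC(=O)NC(=O)NC1=CS(=O)(=O)O[C@@]12[C@@H](CO[Si](C)(C)C(C)(C)C)O[C@@H](n1cc(C)c(=O)n(C)c1=O)[C@@H]2O[Si](C)(C)C(C)(C)C`, giving 3000 nM in a functional assay on CCRF-CEM cells (Homo sapiens); a lower number here means that less compound is tolerated, a higher number that more compound is tolerated
compound 2, `COC(=O)CCNC1=CS(=O)(=O)O[C@@]12[C@@H](CO[Si](C)(C)C(C)(C)C)O[C@@H](n1cc(C)c(=O)n(C)c1=O)[C@@H]2O[Si](C)(C)C(C)(C)C`, giving > 250000 nM in this assay

Compound 2 stands at the edge of what this assay reports: its reading of > 250000 nM is a limit and not a number (the limit of > 250000 nM in this assay, at which 1 of the 2 values shown sits), so of the two measured compounds it is the one tolerated most. Compound 3, `Cc1cn([C@@H]2O[C@H](CO[Si](C)(C)C(C)(C)C)[C@@]3(OS(=O)(=O)C=C3NC(=O)NC(=O)c3ccccc3)[C@H]2O[Si](C)(C)C(C)(C)C)c(=O)n(C)c1=O`, is not yet measured in this assay. It differs from compound 2 by benzoylcarbamoyl in place of 2-(methoxycarbonyl)ethyl on an amine nitrogen. Among the measured compounds shown here, one measured step bears on this position, an at least 83-fold higher number from compound 1 to compound 2 (1.92 log units; beyond the scatter), where an (ethoxycarbonyl)carbamoyl on the amine nitrogen gave way to 2-(methoxycarbonyl)ethyl and the number rose past the limit. Benzoylcarbamoyl shares the carbamoyl pattern of the group that left in that step, so a large fall in the number is expected on going to compound 3. Compound 3 is therefore expected to give about 5000 nM, between 800 nM and 60000 nM, a step of an at least 50-fold lower number from compound 2 to compound 3 (1.69 log units; beyond the scatter).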

Compound 3, half-maximal cytotoxic concentration: 2290 nM
Estimate against measurement, compound 3: 2.2-fold (0.34 log units) above; the measured number falls inside the stated range.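

The fall seen earlier on leaving the carbamoyl pattern now has a counterpart in the other direction: on the amine nitrogen, benzoylcarbamoyl in place of 2-(methoxycarbonyl)ethyl gives an at least 100-fold lower number from compound 2 to compound 3 (2.03 log units; beyond the scatter) in this assay. The far end of the carbamoyl group appears to matter little among the groups shown, as phenyl in place of ethoxy on the carbonyl carbon gives a 1.3-fold lower number from compound 1 to compound 3 (0.12 log units; within the scatter), so the two carbamoyl groups cannot be told apart here. The size of the first of these steps is bounded on one side only, as the reading of compound 2 is a limit: the limit of > 250000 nM in this assay, at which 1 of the 3 values shown sits.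

The compounds shown leave open how much of the carbamoyl group is needed for the low number, for example whether a plain unsubstituted carbamoyl or a simple acetyl on the amine nitrogen would give a number like those of the two carbamoyl compounds. They also leave open whether a 2-carboxyethyl chain would stay at the limit as 2-(methoxycarbonyl)ethyl does.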